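Cyano for Chloro on the Phenyl of Compound 3

This account rests on a few compounds, and the source may have more. Where it says the series, first, only, none or still open, it means among the compounds named here.

Of the compounds shown here, three sharing one core have been measured in a functional assay on mitochondria from heart for inhibition of peroxisomal acyl-coenzyme A oxidase 1 (Rattus norvegicus); on this read-out lower numbers stand for stronger inhibition and higher numbers for weaker inhibition. Compound 1 `Cc1nc2cc(OC[C@H](O)CN3CCN(Cc4noc(-c5ccc(C(C)(C)C)cc5)n4)CC3)ccc2s1` gives 180 nM. Compound 2 `Cc1cccc(-c2nc(CN3CCN(C[C@@H](O)COc4ccc5sc(C)nc5c4)CC3)no2)c1` gives 6500 nM, and compound 3 `Cc1nc2cc(OC[C@H](O)CN3CCN(Cc4noc(-c5cccc(Cl)c5)n4)CC3)ccc2s1` gives 4120 nM, the second highest of the three numbers; its nearest neighbour is compound 2 and its furthest is compound 1. The two large steps, a 36-fold higher number from compound 1 to compound 2 (1.56 log units; beyond the scatter) and a 23-fold higher number from compound 1 to compound 3 (1.36 log units; beyond the scatter), both replace the 4-(tert-butyl)phenyl and do not touch the change now in hand. Compound 4 `Cc1nc2cc(OC[C@H](O)CN3CCN(Cc4noc(-c5cccc(C#N)c5)n4)CC3)ccc2s1` differs from compound 3 by cyano in place of chloro on an aromatic carbon. Within the data shown here, the one measured step that bears on it is the swap of a small group at the same place, a 1.6-fold lower number from compound 2 to compound 3 (0.20 log units; within the scatter), which stayed within the scatter. On that basis the expected step in this assay is a 1.1-fold higher number from compound 3 to compound 4 (0.04 log units; within the scatter), none beyond the scatter. Compound 4 is therefore estimated at 4500 nM, with a range from 1500 nM to 14000 nM.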

Compound 4, half-maximal inhibitory concentration: 13400 nM
For compound 4 the middle estimate is 3.0-fold (0.47 log units) below the measured one; low and high end bracket the measured number.
By their numbers in this assay, from the lowest: compound 1; then compounds 3 and 2 (each within the scatter of the next); then compound 4.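

In this assay, the small group on this phenyl ring, meta to a large group, proves not to be freely exchangeable: a 3.3-fold higher number from compound 3 to compound 4 (0.51 log units; beyond the scatter) lies beyond the scatter, whereas the swap of methyl for chloro had stayed within it. Cyano also separates from methyl, with a 2.1-fold higher number from compound 2 to compound 4 (0.31 log units; beyond the scatter), and a 74-fold higher number from compound 1 to compound 4 (1.87 log units; beyond the scatter) is the widest gap yet from the 4-(tert-butyl)phenyl group. Nothing available explains why cyano parts from chloro and methyl here.

On these data alone, it remains open whether other groups at this place, such as an amine, a carboxylic acid or a methoxy group, would follow cyano or stay with chloro and methyl. Also open, as far as these compounds go, is whether cyano would shift the number similarly on a ring that also carries the tert-butyl group of compound 1.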